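The compounds below may be only part of what the source reports. "The series", "measured", "known", "first", "only" and "open" are said of these compounds alone.

Compound 2 `O=C(Nc1cccc(O)c1)C1c2ccccc2CCN1C(=O)c1ccc(Cl)cc1` carries an acylated ring nitrogen and a 3-hydroxyphenyl amide. In a functional assay on NUGC-3 cells (Homo sapiens) for inhibition, read by sulforhodamine B assay, with a stated time of 48 h (on this read-out lower numbers stand for stronger inhibition of growth and higher numbers for weaker inhibition of growth), compound 2 gives only a limit, > 10000 nM. Compound 1 `O=C(Nc1cccc(C(F)(F)F)c1)C1NCCc2ccccc21`, with the amine nitrogen in the ring left bare, likewise returns only a limit in this assay, > 10000 nM. Within the data shown here, compound 3 `COc1ccc(NC(=O)C2c3ccccc3CCN2C(=O)c2ccc(Cl)cc2)cc1` gives 3630 nM in this assay, and the one numbered step, an at least 2.7-fold lower number from compound 2 to compound 3 (0.44 log units; beyond the scatter), concerns the aryl group on the amide nitrogen rather than the ring nitrogen. Compound 4 `O=C(Nc1cccc(O)c1)C1NCCc2ccccc21` differs from compound 2 by hydrogen in place of (4-chlorophenyl)carbonyl on an amine nitrogen in a ring. Among the measured compounds shown here, no measured step covers this change; the nearest reference is the limit of > 10000 nM in this assay, at which 2 of the 3 values shown sit, which holds compound 1 as well as compound 2. Compound 4 is therefore expected to stay at that limit, with an estimated 20000 nM in this assay, between 8000 nM and 60000 nM. The expected step that the limit leaves unreadable from compound 2 to compound 4 is thus no change beyond the scatter.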

Compound 4, concentration for 50% growth inhibition: > 10000 nM
Compound 4: only a limit was reported; the forecaster's own chance of this, stated with the estimate: 85%; the middle value does not contradict the limit.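

Compound 4 gives only a limit in this assay, > 10000 nM. With compound 1 and compound 2 also at limits, neither step to compound 4 can be read. The compounds shown leave open whether hydrogen in place of (4-chlorophenyl)carbonyl changes growth inhibition at all.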